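Benzyl on the Sulfonamide Nitrogen of Compound 1

A few compounds are considered here, and "the series" means these few. Any claim that something is new, unique, unknown or untested is made for them only; others in the source may bear on it.

Measured compounds:
compound 1, `CCCCc1ccc(CNS(=O)(=O)c2ccccc2)c(=O)n1Cc1ccc(-c2ccccc2-c2nn[nH]n2)cc1`: 25.2%
compound 2, `CCCCc1ccc(CNC(=O)N(C)C)c(=O)n1Cc1ccc(-c2ccccc2-c2nn[nH]n2)cc1`: 28%
compound 3, `CCCCc1ccc(CNS(C)(=O)=O)c(=O)n1Cc1ccc(-c2ccccc2-c2nn[nH]n2)cc1`: 54.8%

In a functional assay on the whole organism (artery) for inhibition, with Rattus norvegicus as the target, at a dose of 3 mg/kg by the intraduodenal route (on this read-out lower numbers stand for less inhibition and higher numbers for more inhibition at the one dose given (going by the name of the read-out)), compound 1 gives the lowest number of the three. Compound 2 is nearest, a number 2.8 percentage points higher from compound 1 to compound 2 (within the scatter), so the two cannot be told apart. Compound 3 lies furthest, a number 29.6 percentage points higher from compound 1 to compound 3 (beyond the scatter), and likewise a number 26.8 percentage points higher from compound 2 to compound 3 (beyond the scatter).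

Compound 4, `CCCCc1ccc(CN(Cc2ccccc2)S(=O)(=O)c2ccccc2)c(=O)n1Cc1ccc(-c2ccccc2-c2nn[nH]n2)cc1`, is not yet measured. It differs from compound 1 in one place: benzyl in place of hydrogen on a sulfonamide nitrogen. Among the compounds with values here, none of the measured steps touches this position. The step from compound 1 to compound 3 changes the group on the sulfonyl sulfur, and the steps to compound 2 replace the sulfonyl altogether; the hydrogen on the sulfonamide nitrogen is kept in all three. The data therefore give no direct guide to the size or direction of this change, and the expectation must stay wide. For compound 4 the step from compound 1 is expected to be a number 3.2 percentage points lower from compound 1 to compound 4 (within the scatter), that is, nothing clearly beyond the scatter. Compound 4 is thus estimated at 22%, with a range from 5% to 45%.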

Compound 4, a percentage reported as inhibition, in the whole organism at one dose (the size of the read-out at that dose, not a potency): 75.7%
Compound 4: middle estimate off by 53.7 percentage points, on the low side, outside the stated range (above it).
By their numbers in this assay, from the lowest: compounds 1 and 2 (each within the scatter of the next); then compound 3; then compound 4.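

In this assay, the sulfonamide nitrogen proves to be a highly responsive position: benzyl in place of hydrogen gives a number 50.5 percentage points higher from compound 1 to compound 4 (beyond the scatter). Compounds 1, 2 and 3 all keep the hydrogen on this nitrogen, so only compound 4 shows that the hydrogen can be replaced without loss at this dose, and that the replacement goes with a large rise in the read-out. Nothing measured here accounts for the rise, so its cause remains unknown.

As far as these compounds go, it remains open whether the aromatic ring of benzyl matters, or whether a plain methyl or a longer chain such as butyl on this nitrogen would do the same. Also open, from the compounds shown here alone, is whether benzyl on the nitrogen of compound 3, with methyl on its sulfonyl sulfur, would raise that compound's number too.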